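Nitro to trifluoromethyl at the anilide of compound 1

The source may hold more compounds than are shown below. What is called first, only, known or untested is meant among the compounds shown, and "the series" means these compounds.

Measured compounds:
compound 1, `CC(C)(C)OC(=O)N1c2ccccc2CC1C(=O)Nc1ccc([N+](=O)[O-])cc1`, 2520 nM
compound 2, `CC(C)(C)OC(=O)N1c2ccccc2CC1C(=O)Nc1cccc(C(F)(F)F)c1`, 6340 nM
compound 3, `CC(C)(C)OC(=O)N1c2ccccc2CC1C(=O)Nc1cc(C(F)(F)F)ccc1C(F)(F)F`, 1520 nM

All three share a core and differ only in the substitution of the anilide ring. In a functional assay on NCI-H23 cells (Homo sapiens) for cytotoxicity (on this read-out lower numbers stand for stronger inhibition of growth and higher numbers for weaker inhibition of growth), compound 1 gives 2520 nM and stands second highest of the three numbers; compound 3 sits nearer, within the scatter, while compound 2 lies beyond it with a higher number. Among the compounds with values here, the one measured step is a 4.2-fold lower number from compound 2 to compound 3 (0.62 log units; beyond the scatter), which adds trifluoromethyl to an aromatic carbon, but it starts from a ring already carrying that group and does not touch a nitro.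

Compound 4, `CC(C)(C)OC(=O)N1c2ccccc2CC1C(=O)Nc1ccc(C(F)(F)F)cc1`, is not yet measured in this assay. From compound 1 the change is trifluoromethyl in place of nitro on an aromatic carbon, para to a large group. Within the data shown here, no measured pair swaps these two groups, so the step cannot be anchored; the spread of the three anilides suggests the number for compound 4 is expected to stay near compound 1, with the step of a 1.4-fold higher number from compound 1 to compound 4 (0.14 log units; within the scatter) taken as the estimate. Compound 4 is thus expected to give 3500 nM, within 1200 nM to 10000 nM.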

Compound 4, concentration for 50% growth inhibition: 3210 nM
Estimate against measurement, compound 4: 1.1-fold (0.04 log units) above; low and high end bracket the measured number.
By their numbers in this assay, from the lowest: compounds 3, 1, 4 and 2 (each within the scatter of the next, the first and the last beyond it).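

In this assay, within the data shown here, the exchange para to a large group gives a 1.3-fold higher number from compound 1 to compound 4 (0.11 log units; within the scatter), the first direct reading of nitro against trifluoromethyl on the anilide ring of the shared core. At this position the read-out does not separate the two groups, and the loss of the hydrogen-bond acceptors and double bond of nitro brings no change beyond the scatter. No measurement in hand accounts for this result or ties it to a property of either group.

On these data alone, whether other groups at this position, such as an amine, a carboxylic acid or a methoxy group, would also leave the number in this range remains open. As far as these compounds go, it is also open whether the same exchange would read alike on a ring with a second substituent, as in compound 3.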